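The source may report more compounds than this note shows. Statements on the series, on what has been measured and on what is new or still open speak of the compounds shown alone.

Compound 2 `COc1cccc(C(=O)NCc2ccc(CNS(=O)(=O)c3ccc(C)cc3)cc2)c1` is one of three measured members of a series built on a shared core, the others being compound 1 `O=C(NCc1ccc(CNS(=O)(=O)c2ccccc2)cc1)c1ccc(F)cc1` and compound 3 `O=C(NCc1ccc(CNS(=O)(=O)c2ccccc2)cc1)c1c(Cl)cc(Cl)cc1Cl`. In an assay on MDA-MB-231 cells for binding affinity to C-X-C chemokine receptor type 4 (Homo sapiens), read by immunofluorescence and microscopy, with stated times of 10 min and 30 min (on this read-out lower numbers stand for an effect already at smaller amounts and higher numbers for an effect only at larger amounts of compound), compound 2 gives 10 nM, level at the digits shown with compound 3, which gives 10 nM; compound 1 gives 100 nM. Within the data shown here, the only single-point step among the measured compounds is a 10-fold lower number from compound 1 to compound 3 (1.00 log units; beyond the scatter), and it concerns the aryl group on the carbonyl carbon, the same position that changes in the step now followed. Compound 4 `Cc1ccc(S(=O)(=O)NCc2ccc(CNC(=O)c3ccccc3C)cc2)cc1` differs from compound 2 by 2-methylphenyl in place of 3-methoxyphenyl on a carbonyl carbon. Among the measured compounds shown here, no measured pair shows a methoxy group exchanged for a methyl group, or a shift in the position of a substituent, so the step from compound 1 to compound 3 indicates only that this position can move the number by a modest amount, not in which direction. Compound 4 is therefore expected to stay close to compound 2, with a 2.0-fold higher number from compound 2 to compound 4 (0.30 log units; within the scatter) as the expected step. The estimate for compound 4 is 20 nM, with a range from 5 nM to 100 nM.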

Compound 4, effective concentration (reported as EC, without a stated level of effect): 100 nM
Compound 4: the middle estimate sits 5.0-fold (0.70 log units) below what was measured, within the range that was stated.
By their numbers in this assay, from the lowest: compounds 2 and 3 (each within the scatter of the next); then compounds 1 and 4 (each within the scatter of the next).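

In this assay the exchange of 3-methoxyphenyl for 2-methylphenyl gives a 10-fold higher number from compound 2 to compound 4 (1.00 log units; beyond the scatter) and so shows that a change in the aryl group on the carbonyl carbon can raise the number as well as lower it, whereas the earlier step at this position, a 10-fold lower number from compound 1 to compound 3 (1.00 log units; beyond the scatter) and nothing else, ran only downward. Replacing one substituted phenyl with another here is therefore not neutral, even though both groups keep the same aromatic ring. No evidence on why the number moves is available.

Among these compounds, the single step leaves open whether the methoxy group, the methyl group or the place of the substituent carries the change. Also open, from the compounds shown here alone, is how the number responds when an amine, a carboxylic acid or a longer chain stands on the carbonyl carbon in place of the aryl group.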